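The source may report more compounds than this note shows. Statements on the series, on what has been measured and on what is new or still open speak of the compounds shown alone.

Series values in a functional assay on the whole organism with Rattus norvegicus as the target; a lower number here means that less compound is needed, a higher number that more compound is needed for the effect:

- compound 1 `CCOCCOC(=O)C(=O)Nc1nc(-c2cc(Br)no2)cs1` gives 11 mg/kg
- compound 2 `CCOCCOC(=O)C(=O)Nc1nc(-c2cc(Br)no2)c(CC)s1` gives 3 mg/kg
- compound 3 `CCOCCOC(=O)C(=O)Nc1nc(-c2cc(OCc3ccccc3)no2)cs1` gives 3.7 mg/kg

Compound 1 has the highest number of the three. The values of compound 2 and compound 3 lie within the scatter of each other, so no order can be drawn between them.

The next comparison starts from compound 3. Compound 4 `CCOCCOC(=O)C(=O)Nc1nc(-c2cc(-c3c(F)cccc3Cl)no2)cs1` has 2-chloro-6-fluorophenyl in place of benzyloxy on an aromatic carbon. The two groups are compared on a five-membered aromatic ring with 1 nitrogen and 1 oxygen.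

The most relevant measurement is a 3.0-fold lower number from compound 1 to compound 3 (0.47 log units; beyond the scatter), seen with benzyloxy in place of bromo at this same carbon. The other measured step, a 3.7-fold lower number from compound 1 to compound 2 (0.56 log units; beyond the scatter), comes from ethyl in place of hydrogen elsewhere on the molecule and bears on this change only indirectly. It does show that a modest step is possible within this assay. Among the compounds with values here, no measured compound carries 2-chloro-6-fluorophenyl, so neither direction is favoured by the data, and no step beyond the scatter is expected.

The estimated change is a 1.2-fold higher number from compound 3 to compound 4 (0.09 log units; within the scatter). For compound 4 the expected value is 4.5 mg/kg, with an estimated range of 1.5 mg/kg to 13 mg/kg.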

Compound 4, dose for half-maximal effect: 1.1 mg/kg
For compound 4 the middle estimate is 4.1-fold (0.61 log units) above the measured one, and the stated range ends above it.
By their numbers in this assay, from the lowest: compound 4; then compounds 2 and 3 (each within the scatter of the next); then compound 1.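

In this assay, the carbon next to the ring nitrogen does not merely accept benzyloxy as a large replacement for bromo: 2-chloro-6-fluorophenyl gives a 3.4-fold lower number from compound 3 to compound 4 (0.53 log units; beyond the scatter), so two groups with the same heavy-atom count are separated beyond the scatter at this position. The change places the six-membered aromatic ring of carbon only without the oxygen of benzyloxy, and it also gives a 10-fold lower number from compound 1 to compound 4 (1.00 log units; beyond the scatter), the largest step at this carbon among the compounds shown. No supporting data bear on why 2-chloro-6-fluorophenyl gives the lower number here.

Open, on these data alone, is what an unsubstituted phenyl, or a phenyl carrying only the chloro or only the fluoro substituent, would give at this carbon, so the contribution of each halogen to the step cannot be separated from that of the ring itself. Also open, as far as these compounds go, are how an amine or a carboxylic acid would read at the same carbon and whether the ethyl group of compound 2 would lower the number further when combined with 2-chloro-6-fluorophenyl.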